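The source may hold more compounds than are shown below. What is called first, only, known or untested is meant among the compounds shown, and "the series" means these compounds.

Compound 1 `COc1ccc([N+](=O)[O-])cc1CSc1nc2cc(NC(=O)NC(C)(C)C)ccc2n1C1CC1` gives 79 nM in an assay on isolated protein for inhibition of Gonadotropin-releasing hormone receptor (Homo sapiens); a higher number here means a weaker inhibitor, a lower number a stronger inhibitor.
Compound 2 `COCCn1c(SCc2cc([N+](=O)[O-])ccc2OC)nc2cc(NC(=O)NC(C)(C)C)ccc21` gives 57 nM in this assay.
Compound 3 `COc1ccc([N+](=O)[O-])cc1CSc1nc2cc(NC(=O)NC(C)(C)C)ccc2n1Cc1ccccc1` gives 28 nM in this assay.

Among these three, compound 1 carries the highest number. Compound 4 `COc1ccc([N+](=O)[O-])cc1CSc1nc2cc(NC(=O)NC(C)(C)C)ccc2n1Cc1ccncc1` differs from compound 1 in a single place: (pyridin-4-yl)methyl in place of cyclopropyl on an aromatic nitrogen. Two measured steps alter the same position on the same core. The step of a 1.4-fold lower number from compound 1 to compound 2 (0.14 log units; within the scatter) stays within the scatter, whereas the step of a 2.8-fold lower number from compound 1 to compound 3 (0.45 log units; beyond the scatter) is a modest but real drop. The group entering compound 4 resembles the benzyl of compound 3, differing only in carrying a ring hetero atom, so a drop of similar size is expected, a 2.3-fold lower number from compound 1 to compound 4 (0.35 log units; beyond the scatter). Compound 4 is therefore estimated to give 35 nM, with a likely range from 15 nM to 90 nM.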

Compound 4, half-maximal inhibitory concentration: 47 nM
For compound 4 the middle estimate is 1.3-fold (0.13 log units) below the measured one; the range from low to high includes it.
By their numbers in this assay, from the lowest: compounds 3, 4, 2 and 1 (each within the scatter of the next, the first and the last beyond it).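

Within this assay, putting a nitrogen into the benzyl ring changes little (a 1.7-fold higher number from compound 3 to compound 4 (0.22 log units; within the scatter)), so this position accepts the ring nitrogen of (pyridin-4-yl)methyl. That group also cannot be separated from cyclopropyl (a 1.7-fold lower number from compound 1 to compound 4 (0.23 log units; within the scatter)) or from 2-methoxyethyl (a 1.2-fold lower number from compound 2 to compound 4 (0.08 log units; within the scatter)), so unlike benzyl it shows no step beyond the scatter from cyclopropyl. Nothing available explains these small steps. Still open, on these data alone, is how an amine or a carboxylic acid on the ring of this group, or a longer chain between ring and aromatic nitrogen, would read here.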